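Two Stilbene Phenols and an Aniline Cousin, Then a Fourth

The source may report more compounds than this note shows. Statements on the series, on what has been measured and on what is new or still open speak of the compounds shown alone.

Compound 1 `Oc1cccc(/C=C/c2ccccc2O)c1`: 27 ug/mL
Compound 2 `Oc1ccc(/C=C/c2cccc(O)c2)cc1`: 6.9 ug/mL
Compound 3 `Nc1cccc(/C=C/c2ccccc2O)c1`: 30.4 ug/mL

These three were tested in a functional assay on HT-29 cells (Homo sapiens) for inhibition, read by MTT assay, with a stated time of 2 days; on this read-out higher numbers stand for weaker inhibition and lower numbers for stronger inhibition. Compound 2 stands apart: compared with it, compound 1 and compound 3 both give numbers beyond the scatter, so compound 2 is the strongest inhibitor of the three. Compound 1 and compound 2 are built from the same atoms joined differently; the difference between the two cores is not broken down here.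

Compound 1 and compound 3 differ in one place, (amino in place of hydroxy on an aromatic carbon). That step gives a 1.1-fold higher number from compound 1 to compound 3 (0.05 log units; within the scatter), so within this pair the swap made no difference that the assay can resolve.

Compound 4 `Nc1cccc(/C=C/c2ccc(O)cc2)c1` has not yet been tested in this assay. It relates to compound 2 exactly as compound 3 relates to compound 1: the change is amino in place of hydroxy on an aromatic carbon, and the surroundings of the swap are the same in both pairs.

Going by the values given here, with only one earlier example of this change to go on, the expectation is that the step from compound 2 to compound 4 is small, estimated at a 1.1-fold higher number from compound 2 to compound 4 (0.04 log units; within the scatter), because the same swap gave a 1.1-fold higher number from compound 1 to compound 3 (0.05 log units; within the scatter). On that basis compound 4 is expected to show about 7.6 ug/mL in this assay, with a likely range from 3.5 ug/mL to 17 ug/mL.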

Compound 4, half-maximal inhibitory concentration: 51 ug/mL
Estimate against measurement, compound 4: 6.7-fold (0.83 log units) below; measured number outside the range, above it.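

Replacing hydroxy with amino on an aromatic carbon clearly weakens inhibition on the core of compound 2: in this assay the swap gives a 7.4-fold higher number from compound 2 to compound 4 (0.87 log units; beyond the scatter). Going by these compounds alone, the size of this change therefore cannot simply be carried from one core to the other, even though the swap itself is identical and the two cores are built from the same atoms joined differently, as the two steps set side by side make plain: the same change on two cores in this assay, a 1.1-fold higher number (0.05 log units; within the scatter) from compound 1 to compound 3 and a 7.4-fold higher number (0.87 log units; beyond the scatter) from compound 2 to compound 4, 6.6-fold (0.82 log units) apart, beyond the scatter of two such steps This shows that the outcome of the swap depends on the core it is made on, but it does not show why, and with only one pair for each core it gives no rule for predicting the swap on any other core.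

As far as these compounds go, it remains open whether the loss seen on the core of compound 2 belongs to the amino group itself or would follow from any replacement of that hydroxy, and a methoxy group or a fluorine atom in the same place on both cores would help separate those two readings. Also open, from the compounds shown here alone, is whether replacing the other hydroxy, the one that stays in both compound 2 and compound 4, would depend on the core in the same way.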